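Carboxy in place of isopropyl: a step without a precedent

The source may hold more compounds than are shown below. What is called first, only, known or untested is meant among the compounds shown, and "the series" means these compounds.

Of the compounds shown here, three sharing one core have been tested in an assay on isolated protein for inhibition of protein kinase C zeta type (Homo sapiens), with a stated time of 4 min, tested at 62.5 uM; on this read-out lower numbers stand for less inhibition and higher numbers for more inhibition at the one concentration tested (going by the name of the read-out). Compound 1, `CC(C)(C)C1=NN(c2ccc(F)cc2)C(c2ccc(O)cc2)C1`, gives 95.5%; compound 2, `CC(C)(C)C1=NN(c2ccc(C(F)(F)F)cc2)C(c2ccc(O)cc2)C1`, gives 94.2%; and compound 3, `CC(C)c1ccc(N2N=C(C(C)(C)C)CC2c2ccc(O)cc2)cc1`, gives 54.9%. Compound 3 stands lowest of the three: a number 40.6 percentage points lower from compound 1 to compound 3 (beyond the scatter), and a number 39.3 percentage points lower from compound 2 to compound 3 (beyond the scatter), while a number 1.3 percentage points lower from compound 1 to compound 2 (within the scatter). So swapping fluoro for trifluoromethyl on the aromatic carbon changed little, whereas isopropyl in the same place cost a great deal.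

Compound 4, `CC(C)(C)C1=NN(c2ccc(C(=O)O)cc2)C(c2ccc(O)cc2)C1`, is the next step from compound 3: carboxy in place of isopropyl on an aromatic carbon. Going by the values given here, no measured step bears directly on a carboxy group here; the two large steps only show that isopropyl at this position lowers the read-out, and that the two smaller groups fluoro and trifluoromethyl give high numbers. As far as these compounds go, removing isopropyl is therefore expected to recover some of the lost inhibition, but how far a carboxy group goes remains open, so the expectation is wide. In this assay the expected step is a number 20.1 percentage points higher from compound 3 to compound 4 (beyond the scatter), and compound 4 is estimated at 75%, within a range from 40% to 98%.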

Compound 4, a percentage reported as inhibition, at one concentration (the size of the read-out at that concentration, not a potency): 47.9%
Estimate against measurement, compound 4: 27.1 percentage points above; measured number inside the range.
By their numbers in this assay, from the lowest: compounds 4 and 3 (each within the scatter of the next); then compounds 2 and 1 (each within the scatter of the next).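

In this assay, isopropyl and carboxy, groups built from different atoms, cannot be told apart at this place on the aromatic ring, with a number 7 percentage points lower from compound 3 to compound 4 (within the scatter), so the low number is not peculiar to isopropyl. Replacing isopropyl therefore does not by itself restore the high numbers: carboxy remains well short of both trifluoromethyl and fluoro, with a number 46.3 percentage points lower from compound 2 to compound 4 (beyond the scatter) and a number 47.6 percentage points lower from compound 1 to compound 4 (beyond the scatter), and the four compounds now form a high pair and a low pair. Nothing available explains why these groups fall into these two pairs.

As far as these compounds go, four groups are too few to show what decides membership of each pair, so it remains open whether a chloro group, a methyl group or an amine at the same place would join compounds 1 and 2 or compounds 3 and 4. The methyl ester and the primary amide of the carboxy group would also be informative, since each would show whether a close relative of carboxy stays with the low pair.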